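This account rests on a few compounds, and the source may have more. Where it says the series, first, only, none or still open, it means among the compounds named here.

Compound 1 `N[C@H]1CC[C@H](Nc2c(C(=O)NCc3ccc(F)cc3)nc(N3CCCCC3)c3cccnc23)CC1` gives 5000 nM in a functional assay on MDA-MB-435 cells (Homo sapiens) for cytotoxicity, read by MTT assay, with a stated time of 72 h; on this read-out higher numbers stand for weaker inhibition and lower numbers for stronger inhibition.
Compound 2 `COC(=O)CNc1c(C(=O)NCc2ccc(F)cc2)nc(Br)c2cccnc12` gives 10000 nM.
Compound 3 `CNCCCNc1c(C(=O)NCc2ccc(F)cc2)nc(Br)c2cccnc12` gives 11000 nM.

Compound 1 holds the lowest of the three numbers in this assay; compound 2 sits within the usual scatter of it, while compound 3 lies beyond that scatter. Compound 4 `N[C@H]1CC[C@H](Nc2c(C(=O)NCc3ccc(F)cc3)nc(Br)c3cccnc23)CC1` differs from compound 1 in one place: bromo in place of piperidin-1-yl on an aromatic carbon. Within the data shown here, the only measured step, a 1.1-fold higher number from compound 2 to compound 3 (0.04 log units; within the scatter), alters the chain on the amine and not this place, so it does not bear directly on the change. Compounds 2 and 3, which both carry bromo at this place, sit at the higher end of the three numbers. Compound 4 is therefore expected to show a modestly higher number, a 1.8-fold higher number from compound 1 to compound 4 (0.26 log units; within the scatter), giving an estimate of 9000 nM with a range from 4000 nM to 20000 nM.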

Compound 4, half-maximal inhibitory concentration: 6000 nM
Compound 4: the middle estimate sits 1.5-fold (0.18 log units) above what was measured; low and high end bracket the measured number.
By their numbers in this assay, from the lowest: compounds 1, 4, 2 and 3 (each within the scatter of the next, the first and the last beyond it).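

In (this assay) the exchange of piperidin-1-yl for bromo on this aromatic carbon stays within the scatter (a 1.2-fold higher number from compound 1 to compound 4 (0.08 log units; within the scatter)), so with the 4-aminocyclohexyl group held fixed, the larger ring and the single bromine atom cannot be told apart here. With bromo held fixed, the two changes on the nitrogen also stay within the scatter (a 1.8-fold lower number from compound 3 to compound 4 (0.26 log units; within the scatter); a 1.7-fold lower number from compound 2 to compound 4 (0.22 log units; within the scatter)). Nothing measured alongside these values offers an explanation for them.

Going by these compounds, whether morpholin-4-yl or a simple amine on this carbon would move the number beyond the scatter remains open. So does whether the exchange reads the same with a 3-(methylamino)propyl chain on the nitrogen.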